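Swapping the Nitrile of Compound 1 for a tert-Butyl Group

A few compounds are considered here, and "the series" means these few. Any claim that something is new, unique, unknown or untested is made for them only; others in the source may bear on it.

Compound 1 `CC1CCN(C2CCN(S(=O)(=O)c3ccc(C#N)cc3)CC2)CC1`: 2800 nM
Compound 2 `CC1CCN(C2CCN(S(=O)(=O)c3cccc(Cl)c3)CC2)CC1`: > 5000 nM, a limit of the assay rather than a number

Among the compounds with values here, in a functional assay on DLD-1 cells (Homo sapiens) for antiproliferative activity, read by CellTiter-Glo, with a stated time of 72 h (on this read-out lower numbers stand for stronger inhibition and higher numbers for weaker inhibition), compound 1 gives 2800 nM, the only plain number among the two values shown. The value of compound 2 is a limit of the assay (the limit of > 5000 nM in this assay, at which 1 of the 2 values shown sits). Compound 3 `CC1CCN(C2CCN(S(=O)(=O)c3ccc(C(C)(C)C)cc3)CC2)CC1` differs from compound 1 by tert-butyl in place of cyano on an aromatic carbon. Within the data shown here, the single measured step, an at least 1.7-fold higher number from compound 1 to compound 2 (0.25 log units; that floor lies within the scatter), alters a different part of the aryl group, so it bears only loosely on this change, and its floor lies within the scatter. The step of a 1.3-fold higher number from compound 1 to compound 3 (0.10 log units; within the scatter) is therefore expected to stay within or near the scatter, with a slight lean toward a higher number. Compound 3 is estimated at 3500 nM, ranging from 1200 nM to 10000 nM.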

Compound 3, half-maximal inhibitory concentration: > 5000 nM
Compound 3: a limit, no number (the forecaster's own chance of this, stated with the estimate: 35%); middle value at least 1.4-fold (0.15 log units) from the limit.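

In this assay compound 3 gives > 5000 nM, which is a limit of the assay and not a number. Putting tert-butyl on this aromatic carbon gives an at least 1.7-fold higher number from compound 1 to compound 3 (0.25 log units; that floor lies within the scatter), so this change shows no gain in potency, though the size of any loss stays hidden. Compound 3 now joins compound 2 at the same ceiling, and the read-out cannot separate them there: the limit of > 5000 nM in this assay, at which 2 of the 3 values shown sit.

Going by these compounds, whether an amine or a methoxy group at this position would keep or improve on the activity of compound 1 remains open. So does how weak compound 2 and compound 3 really are.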